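The source may hold more compounds than are shown below. What is called first, only, known or untested is meant among the compounds shown, and "the series" means these compounds.

Compound 1, `CCc1nnc(SCC(=O)c2ccc(C)cc2)n1N1C(=O)c2ccccc2C1=O`, in a functional assay on HepG2 cells (Homo sapiens) for cytotoxicity, read by MTT assay, with a stated time of 48 h; a lower number here means a stronger inhibitor, a higher number a weaker inhibitor: > 200000 nM.
Compound 2, `COc1cc(-c2nnc(SCC(=O)c3ccc(Cl)cc3)n2N2C(=O)c3ccccc3C2=O)cc(OC)c1OC`, in this assay: 22000 nM.

The value of compound 1 is a limit of this assay, > 200000 nM, and not a measured number; this is the limit of > 200000 nM in this assay, at which 1 of the 2 values shown sits. Within the data shown here, compound 2 is therefore the only compound with a measured number in this assay, and it gives 22000 nM.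

Compound 3, `COc1cc(-c2nnc(SCC(=O)c3ccc(C)cc3)n2N2C(=O)c3ccccc3C2=O)cc(OC)c1OC`, is not yet measured. It differs from compound 2 by methyl in place of chloro on an aromatic carbon. Among the measured compounds shown here, no measured pair shows this change on its own, since compound 1 and compound 3 also differ elsewhere. The swap is small, and the expectation for the step from compound 2 to compound 3 is a slight move toward weaker inhibition or none beyond the scatter, a 1.6-fold higher number from compound 2 to compound 3 (0.20 log units; within the scatter). Compound 3 is accordingly expected to give about 35000 nM, within 12000 nM to 150000 nM.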

Compound 3, half-maximal inhibitory concentration: 9440 nM
For compound 3 the middle estimate is 3.7-fold (0.57 log units) above the measured one; measured number outside the range, below it.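

Going from 4-chlorophenyl to 4-methylphenyl gives a 2.3-fold lower number from compound 2 to compound 3 (0.37 log units; beyond the scatter) in this assay, so this position responds even when one heavy atom is swapped for another. With 4-methylphenyl held in place, the other substituted site on the shared core shows a much larger change, as 3,4,5-trimethoxyphenyl in place of ethyl gives an at least 21-fold lower number from compound 1 to compound 3 (1.32 log units; beyond the scatter). The value of compound 1 is a limit and not a number, so the true size of that step remains unknown: the limit of > 200000 nM in this assay, at which 1 of the 3 values shown sits.

On these data alone, only chloro and methyl are compared at the first position, so the effect of a methoxy group, an amine or a bare hydrogen there remains open. At the second site, a plain phenyl ring or a longer alkyl chain could show how much of the 3,4,5-trimethoxyphenyl group is needed.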